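Swapping a dichlorophenyl for a methoxyphenyl on the tetrazole arm

The compounds below may be only part of what the source reports. "The series", "measured", "known", "first", "only" and "open" are said of these compounds alone.

Measured so far:
compound 1 `Cc1cc(NC(=O)Cn2nnc(-c3ccccc3)n2)n(C2CCS(=O)(=O)CC2)n1`, > 25%
compound 2 `CC1CC1c1cc(NC(=O)Cn2nnc(-c3ccccc3)n2)n(C2CCCCC2)n1`, 78%
compound 3 `Cc1cc(NC(=O)Cn2nnc(-c3cc(Cl)cc(Cl)c3)n2)n(C2CCCCC2)n1`, 82%

In an assay on HEK293 cells for activation of Kir3.1/Kir3.2 (Homo sapiens), read by thallium flux (on this read-out lower numbers stand for smaller maximal responses and higher numbers for larger maximal responses), compound 3 gives 82%. Compound 2 gives 78% in this assay, and the two numbers sit within the usual scatter of each other, so neither can be called the larger response. Compound 1 reaches only a limit of the assay, > 25%, so it offers no number to compare with the limit of > 25% in this assay, at which 1 of the 3 values shown sits.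

Compound 4 `COc1cccc(-c2nnn(CC(=O)Nc3cc(C)nn3C3CCCCC3)n2)c1` has not been measured. It keeps the shared core of compound 3 and changes one group on the five-membered aromatic ring with four nitrogens: 3-methoxyphenyl in place of 3,5-dichlorophenyl on an aromatic carbon. Going by the values given here, no measured pair shows what such a change does to the maximal response, so the expectation rests on compound 3 alone. The step from the dichlorophenyl to the methoxyphenyl is expected to lower the response somewhat, as a number 17 percentage points lower from compound 3 to compound 4 (beyond the scatter), though a move within the scatter cannot be ruled out. Compound 4 is therefore estimated at 65%, with a range from 40% to 90%.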

Compound 4, largest response reached (Emax), in percent of the reference or control that the assay uses: 76%
Compound 4: middle estimate off by 11 percentage points, on the low side; the range from low to high includes it.
By their numbers in this assay, from the lowest: compounds 4, 2 and 3 (each within the scatter of the next).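

This is the only pair shown that differs in one place, so it gives the first direct reading for the group on the aromatic carbon of the five-membered aromatic ring with 4 nitrogen. In this assay, placing 3-methoxyphenyl there instead of 3,5-dichlorophenyl gives a number 6 percentage points lower from compound 3 to compound 4 (within the scatter) and so no change that can be told from scatter, even though the entering group has a hydrogen-bond acceptor that the leaving group lacks. Nothing measured here explains this outcome.

Still open, on these data alone, is whether any group at this position can move the maximal response beyond the scatter, for example an amine or a carboxylic acid on the phenyl ring in place of the methoxy group. The pair also cannot separate the contribution of each chlorine, as both leave in the same step.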